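Propanoyl and butanoyl ketones on two pyrazole arrangements

The source may report more compounds than this note shows. Statements on the series, on what has been measured and on what is new or still open speak of the compounds shown alone.

Measured so far:
compound 1 `CCC(=O)c1cc(-c2ccc(S(N)(=O)=O)cc2)n(-c2ccc(Cl)cc2)n1` — 41900 nM
compound 2 `CCCC(=O)c1cc(-c2ccc(S(N)(=O)=O)cc2)n(-c2ccc(Cl)cc2)n1` — 25800 nM
compound 3 `CCC(=O)c1cc(-c2ccc(S(N)(=O)=O)cc2)nn1-c1ccc(Cl)cc1` — 49600 nM

Compounds 1 and 2 share one core; compound 3 has the same atoms joined differently, and the difference between the two cores is not broken down here. In a physicochemical assay for solubility, read by HPLC, in phosphate buffer, measured as kinetic solubility, at pH 7.4 (on this read-out higher numbers stand for higher solubility and lower numbers for lower solubility), compound 1 gives 41900 nM and compound 2 gives 25800 nM. The change between them is methyl in place of hydrogen on a saturated chain carbon, two bonds along the chain from a carbonyl carbon, and the step it made is a 1.6-fold lower number from compound 1 to compound 2 (0.21 log units; within the scatter).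

Compound 4 `CCCC(=O)c1cc(-c2ccc(S(N)(=O)=O)cc2)nn1-c1ccc(Cl)cc1` is not yet measured. It stands to compound 3 as compound 2 stands to compound 1: the change is methyl in place of hydrogen on a saturated chain carbon, two bonds along the chain from a carbonyl carbon, the same change at the same place. Because the earlier step was a 1.6-fold lower number from compound 1 to compound 2 (0.21 log units; within the scatter), a step of similar size is expected from compound 3, namely a 1.6-fold lower number from compound 3 to compound 4 (0.20 log units; within the scatter). Compound 4 is therefore estimated at 31000 nM in this assay, expected to fall between 18000 nM and 55000 nM.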

Compound 4, solubility: 400 nM
The estimate for compound 4 lay 78-fold (1.89 log units) above the measured number, and the stated range ends above it.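

In this assay, methyl in place of hydrogen on a saturated chain carbon, two bonds along the chain from a carbonyl carbon, gives a 120-fold lower number from compound 3 to compound 4 (2.09 log units; beyond the scatter) and is large, while the same change on the core of compound 1 gives a 1.6-fold lower number from compound 1 to compound 2 (0.21 log units; within the scatter) and stays within the scatter. The step therefore did not carry from one core to the other in this pair, but one pair on each core shows neither a general rule for the series nor how other groups would behave. No evidence bears on why the two steps differ.

From the compounds shown here alone, it remains open whether a longer chain such as pentanoyl, or an amine at the same place, would follow the large step on the core of compound 3 or the small one on the core of compound 1.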